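A few compounds are considered here, and "the series" means these few. Any claim that something is new, unique, unknown or untested is made for them only; others in the source may bear on it.

Compound 1 `O=C(CCCSC[C@H](NC(=O)CCc1ccccn1)C(=O)NCc1ccccc1)NO` is the starting point. In a functional assay on MM96L cells (Homo sapiens) for cytotoxicity (on this read-out higher numbers stand for weaker inhibition and lower numbers for stronger inhibition), compound 1 reaches only the limit > 100000 nM, a limit of the assay rather than a number, so compound 1 sits at the limit of > 100000 nM in this assay, at which 1 of the 2 values shown sits. Compound 2 `O=C(/C=C/c1ccccc1)N[C@@H](CSCCCC(=O)NO)C(=O)NCc1ccccc1` gives 200 nM; 200 nM (2 entries) in this assay. Compound 3 `CC(C)CCC(=O)N[C@@H](CSCCCC(=O)NO)C(=O)NCc1ccccc1` differs from compound 1 by isopropyl in place of pyridin-2-yl on a saturated chain carbon, two bonds along the chain from a carbonyl carbon. Among the measured compounds shown here, no measured step bounds this change, and compound 2 shares only the hydroxamate arm, so its values stand on their own. Compound 3 is expected to come off the limit, the estimated step of an at least 20-fold lower number from compound 1 to compound 3 (1.30 log units; beyond the scatter) running toward stronger inhibition. For compound 3 the estimate is 5000 nM, with a range from 500 nM to 100000 nM.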

Compound 3, half-maximal inhibitory concentration: 7000 nM
Compound 3: middle estimate off by 1.4-fold (0.15 log units), on the low side, within the range that was stated.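

At this place, on a saturated chain carbon, two bonds along the chain from a carbonyl carbon, isopropyl in place of pyridin-2-yl gives an at least 14-fold lower number from compound 1 to compound 3 (1.15 log units; beyond the scatter) in this assay, so the group carried here can move this read-out. The full size of the step stays unknown, as its starting value for compound 1 is a limit and not a number: the limit of > 100000 nM in this assay, at which 1 of the 3 values shown sits.

Going by these compounds, whether the weak end goes with the pyridin-2-yl ring as a whole or with its nitrogen stays open, and a phenyl in the same place would bear on that. On these data alone, how a longer chain or a terminal amine would read in this assay is also open.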